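This account rests on a few compounds, and the source may have more. Where it says the series, first, only, none or still open, it means among the compounds named here.

Working notes on the series.

The series is read in a functional assay on A549 cells (Homo sapiens) for cytotoxicity, read by MTT assay, with a stated time of 68 h; a lower number here means a stronger inhibitor, a higher number a weaker inhibitor. Within the data shown here, compound 1 `O=C(Nc1cccc(-c2cccc(NC(=O)C(Cl)Cl)c2)c1)C(Cl)Cl` carries two ((dichloromethyl)carbonyl)amino groups on the shared core and gives 47900 nM, the highest of the three numbers measured so far. Compound 3 `Cc1ccccc1-c1cccc(NC(=O)C(Cl)Cl)c1`, in which one of those groups is replaced by a methyl, gives 9860 nM, and compound 2 `CCOc1cccc(-c2cc(NC(=O)C(Cl)Cl)cc(-c3cccc(OCC)c3)c2)c1`, which keeps a single ((dichloromethyl)carbonyl)amino group and carries two ethoxy groups on its outer rings, gives 8830 nM. Both stand beyond the scatter below compound 1, and the two of them lie within the scatter of each other, so no order between compound 2 and compound 3 can be read.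

Compound 4 `COc1cccc(-c2cccc(NC(=O)C(Cl)Cl)c2)c1` has not yet been measured in this assay. It differs from compound 1 in one place: methoxy in place of ((dichloromethyl)carbonyl)amino on an aromatic carbon. Among the measured compounds shown here, no step between two measured compounds has exactly this change, so what is expected rests on the values at hand. Both compounds that keep only one ((dichloromethyl)carbonyl)amino group give lower numbers than compound 1, and compound 4 is therefore expected to follow the same direction, with a step from compound 1 to compound 4 estimated at a 4.4-fold lower number from compound 1 to compound 4 (0.64 log units; beyond the scatter), beyond the scatter. For compound 4 the value in this assay is estimated at 11000 nM, with a range from 4000 nM to 30000 nM.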

Compound 4, half-maximal inhibitory concentration: 4310 nM
Beside the measured number, compound 4's estimate is 2.6-fold (0.41 log units) above it, and the stated range covers the measured number.
By their numbers in this assay, from the lowest: compound 4; then compounds 2 and 3 (each within the scatter of the next); then compound 1.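

In this assay, the step of an 11-fold lower number from compound 1 to compound 4 (1.05 log units; beyond the scatter) gives the series its first direct reading of a change in one place, with methoxy in place of ((dichloromethyl)carbonyl)amino on an aromatic carbon, meta to a large group. At this position, a second ((dichloromethyl)carbonyl)amino group is therefore not required for the lower number, and its replacement by methoxy gives a large step in the direction of stronger inhibition. The change removes 6 heavy atoms and 1 hydrogen-bond donor and brings in 2 heavy atoms and no donor, so this single step cannot separate size from donor count, and no measurement at hand bears on the reason for the step.

Going by these compounds, whether the lower number depends on methoxy itself or simply on the loss of ((dichloromethyl)carbonyl)amino remains open, and a plain hydrogen, a hydroxyl or an amine on the same aromatic carbon would help to distinguish the two. Also open, on these data alone, is whether the remaining ((dichloromethyl)carbonyl)amino group matters, which a simple acetamide in its place would test.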